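This account rests on a few compounds, and the source may have more. Where it says the series, first, only, none or still open, it means among the compounds named here.

Measured compounds:
Compound 1, `COCC(=O)NC1CCN(c2nc(C)c3cc(NC(=O)/C=C/c4ccc(OC(F)(F)F)cc4)ccc3n2)CC1`: 58%
Compound 2, `Cc1nc(N2CCC(O)(C3CCC3)CC2)nc2ccc(NC(=O)/C=C/c3ccc(Cl)cc3)cc12`: "not determined" (no result reported)
Compound 3, `Cc1nc(N2CCC(O)(C3CC3)CC2)nc2ccc(NC(=O)COc3ccc(OC(F)(F)F)cc3)cc12`: "not determined" (no result reported)

Three compounds of the same series were taken into an ADME assay on microsomes from liver (Homo sapiens) for metabolic stability, with a stated time of 30 min; on this read-out higher numbers stand for a more stable compound and lower numbers for a less stable compound. Going by the values given here, compound 1 is the only one for which a number is reported; in this assay compound 1 gives 58%. For compound 2 and compound 3 no result is reported, so compound 1 stands alone and cannot be placed above or below any neighbour.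

Compound 4, `Cc1nc(N2CCC(N3CCCC3=O)CC2)nc2ccc(NC(=O)/C=C/c3ccc(OC(F)(F)F)cc3)cc12`, has not yet been measured in this assay. It differs from compound 1 in one place: 2-oxopyrrolidin-1-yl in place of ((methoxymethyl)carbonyl)amino on a saturated ring carbon. Everything else in the molecule, including the shared core and the amide-linked side chain, is kept unchanged.

Among the compounds with values here, no pair of measured compounds differs in a single place, so there is no measured step to lean on. Within the data shown here, the only anchor is the value of compound 1, 58%. The exchanged groups are counted as the same size, one carbonyl stays and the hydrogen-bond donor is removed, and nothing measured speaks to such a swap. The expected step is a number 3 percentage points lower from compound 1 to compound 4 (within the scatter), which is not expected to reach beyond the usual scatter. Compound 4 is therefore estimated at 55% in this assay, with a range from 35% to 75%.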

Compound 4, percent of the compound remaining: 76%
For compound 4 the middle estimate is 21 percentage points below the measured one, outside the stated range (above it).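

In this assay, going by these compounds alone, putting 2-oxopyrrolidin-1-yl in place of ((methoxymethyl)carbonyl)amino on the saturated ring carbon gives a number 18 percentage points higher from compound 1 to compound 4 (beyond the scatter), the only measured step in this small set. It shows that the read-out responds to a change at this place, three ring bonds from the ring nitrogen, even when the leaving and entering groups have the same number of heavy atoms and each carries a carbonyl. By the counts, the entering group has a five-membered ring and no hydrogen-bond donor, while the leaving group is an open chain with a donor and one more acceptor, but no available evidence explains the step.

The compounds shown leave open which of these differences matters, and a version of the open chain with a methyl group in place of the amide hydrogen would separate the loss of the donor from the closing of the ring. As far as these compounds go, how a simple amine, a carboxylic acid or a longer chain on the same ring carbon would read in this assay also remains open.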